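Nitrophenyl in place of difluorophenyl on the thioether arm

A few compounds are considered here, and "the series" means these few. Any claim that something is new, unique, unknown or untested is made for them only; others in the source may bear on it.

Compound 2 `Fc1cccc(F)c1CSc1nnc(-c2ccncc2)n1-c1ccccc1` gives 22100 nM in a functional assay on HCT-116 cells (Homo sapiens) for inhibition, read by MTT assay, with a stated time of 48 h (a higher number here means a weaker inhibitor, a lower number a stronger inhibitor), the top of the two numbers measured, yet within the scatter of compound 1 `Fc1ccc(CSc2nnc(-c3ccncc3)n2-c2ccccc2)cc1`, which gives 12800 nM. Among the measured compounds shown here, the only step in hand, a 1.7-fold higher number from compound 1 to compound 2 (0.24 log units; within the scatter), is small. Compound 3 `O=[N+]([O-])c1ccccc1CSc1nnc(-c2ccncc2)n1-c1ccccc1` carries 2-nitrophenyl in place of 2,6-difluorophenyl on a saturated chain carbon bound to a sulfur. For the measured compounds named here, no measured step involves a nitro group, so the fluorine-pattern step is the sole guide, and it stayed within the scatter. A step of a 1.1-fold lower number from compound 2 to compound 3 (0.04 log units; within the scatter) is therefore expected, with no shift beyond the scatter in either direction. Compound 3 is estimated at 20000 nM, in the range 7000 nM to 60000 nM.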

Compound 3, half-maximal inhibitory concentration: > 50000 nM
Compound 3 was reported as a limit; the forecaster's own chance of this, stated with the estimate: 15%; at least 2.5-fold (0.39 log units) between middle value and limit.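

Compound 3 stands only as a limit in this assay: the limit of > 50000 nM in this assay, at which 1 of the 3 values shown sits.
This position on a saturated chain carbon bound to a sulfur is therefore not indifferent to the aryl group, a point the two fluorinated compounds alone did not show.
The 2-nitrophenyl change gives an at least 2.2-fold higher number from compound 2 to compound 3 (0.35 log units; beyond the scatter) and an at least 3.9-fold higher number from compound 1 to compound 3 (0.59 log units; beyond the scatter).

On these data alone, the full size of both steps stays open, as these figures rest on a limit.
Also open, as far as these compounds go, is how an amine or a carboxylic acid in place of the nitro group, or a longer chain in place of the saturated chain carbon, would read in this assay.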